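The source may report more compounds than this note shows. Statements on the series, on what has been measured and on what is new or still open speak of the compounds shown alone.

Working notes on the series. In a functional assay on PC-3 cells (Homo sapiens) for cytotoxicity, read by MTT assay, with a stated time of 72 h (on this read-out lower numbers stand for stronger inhibition and higher numbers for weaker inhibition), compound 1 `COc1ccc(C(=O)c2cc(OC)c(OC)c(OC)c2)cc1NC(=O)/C=C/c1cc(OC)c(OC)c(OC)c1` gives 3900 nM, compound 2 `COc1ccc(C(=O)c2cc(OC)c(OC)c(OC)c2)cc1NC(=O)/C=C/c1ccc(OC)c(OC)c1` gives 7500 nM and compound 3 `COc1ccc(/C=C/C(=O)Nc2cc(C(=O)c3cc(OC)c(OC)c(OC)c3)cc(OC)c2OC)cc1OC` gives 5400 nM. Compound 3 thus stands second highest of the three numbers, nearest compound 1 and furthest compound 2, with both gaps within the scatter. Compound 4 `COc1cc(C(=O)c2cc(OC)c(OC)c(OC)c2)cc(NC(=O)/C=C/c2ccc(C(F)(F)F)cc2)c1OC` differs from compound 3 by 4-(trifluoromethyl)phenyl in place of 3,4-dimethoxyphenyl on a double-bonded chain carbon bound to a double-bonded chain carbon. For the measured compounds named here, the measured steps that bear on this are a 1.9-fold higher number from compound 1 to compound 2 (0.28 log units; within the scatter) and a 1.4-fold lower number from compound 2 to compound 3 (0.14 log units; within the scatter), both within the scatter; neither involves a trifluoromethyl, so the entering group has no precedent in this set. The expected step is therefore none beyond the scatter, if anything toward a higher number, a 1.5-fold higher number from compound 3 to compound 4 (0.17 log units; within the scatter). Compound 4 is estimated at 8000 nM in this assay, with a range from 3000 nM to 25000 nM.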

Compound 4, half-maximal inhibitory concentration: 4200 nM
Estimate against measurement, compound 4: 1.9-fold (0.28 log units) above, within the range that was stated.
By their numbers in this assay, from the lowest: compounds 1, 4, 3 and 2 (each within the scatter of the next).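

On a double-bonded chain carbon bound to a double-bonded chain carbon, 4-(trifluoromethyl)phenyl in place of 3,4-dimethoxyphenyl gives a 1.3-fold lower number from compound 3 to compound 4 (0.11 log units; within the scatter) in this assay. The earlier steps shown here changed a single methoxy on an aromatic carbon, whereas this one replaces the whole aryl group with one that has no hydrogen-bond acceptors, and the step still lies within the scatter. No measurement bears on the reason for this result.

Going by these compounds, whether an amine or a carboxylic acid on this phenyl ring would give a step beyond the scatter remains open.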